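The compounds below may be only part of what the source reports. "The series", "measured", "known", "first", "only" and "open" are said of these compounds alone.

Working notes on the series. In a functional assay on HT-29 cells (Homo sapiens) for antiproliferative activity, read by sulforhodamine B assay, with a stated time of 48 h (on this read-out lower numbers stand for stronger inhibition and higher numbers for weaker inhibition), compound 1 `CC(=O)Nc1ccc(S(=O)(=O)Oc2ccccc2I)cc1` gives 23000 nM, compound 2 `CC(C)(C)C(=O)Nc1ccc(S(=O)(=O)Oc2ccccc2I)cc1` gives 9500 nM, and compound 3 `CCCCCNC(=O)Nc1ccc(S(=O)(=O)Oc2ccccc2I)cc1` gives 6600 nM. The number for compound 3 is the lowest of the three shown, but it sits within the scatter of compound 2 and is separated by more than the scatter only from compound 1. All measured steps alter the group on the carbonyl carbon: a 2.4-fold lower number from compound 1 to compound 2 (0.38 log units; beyond the scatter), a 3.5-fold lower number from compound 1 to compound 3 (0.54 log units; beyond the scatter), a 1.4-fold lower number from compound 2 to compound 3 (0.16 log units; within the scatter).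

Compound 4 `O=C(Nc1ccc(S(=O)(=O)Oc2ccccc2I)cc1)NC1CC1` differs from compound 3 at the amide-type nitrogen: cyclopropyl in place of pentyl on an amide-type nitrogen. Among the measured compounds shown here, no measured step changes this position, so none bears on it directly. The steps that exist are modest at most, and the pair compound 2 and compound 3 lies within the scatter, so in this assay a small step is expected, probably not beyond the scatter, if anything toward a slightly higher number. For compound 4 the estimate is 9000 nM, with a range from 4000 nM to 20000 nM. The expected step is a 1.4-fold higher number from compound 3 to compound 4 (0.13 log units; within the scatter).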

Compound 4, half-maximal inhibitory concentration: 14000 nM
The estimate for compound 4 lay 1.6-fold (0.19 log units) below the measured number, and the stated range covers the measured number.
By their numbers in this assay, from the lowest: compounds 3, 2, 4 and 1 (each within the scatter of the next, the first and the last beyond it).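

In this assay, among the compounds shown here, this is the first direct reading at the amide-type nitrogen, and cyclopropyl in place of pentyl gives a 2.1-fold higher number from compound 3 to compound 4 (0.33 log units; beyond the scatter), so the group on this nitrogen moves the number by a modest step beyond the scatter. The cyclopropylamino group is not separated from the groups on the carbonyl carbon of the two other compounds, with a 1.5-fold higher number from compound 2 to compound 4 (0.17 log units; within the scatter) and a 1.6-fold lower number from compound 1 to compound 4 (0.22 log units; within the scatter), both within the scatter. No measurement shown gives a reason for the step at the nitrogen.

The change replaces an open chain with a smaller ring, so the compounds shown cannot tell the loss of chain length from the presence of the ring. As far as these compounds go, a propyl chain or a cyclopentyl ring on the same nitrogen would separate the two, and a chain ending in an amine remains open as well.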